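Replacing isopropoxycarbonyl with propargyloxy: an expected step

The source may report more compounds than this note shows. Statements on the series, on what has been measured and on what is new or still open speak of the compounds shown alone.

Measured in a functional assay on the whole organism for inhibition, with Scenedesmus acutus as the target; on this read-out higher numbers stand for weaker inhibition and lower numbers for stronger inhibition:
- Compound 1 `CCCOC(=O)c1cc(N2C(=O)C3=C(CCCC3)C2=O)ccc1Cl`: 1120 nM
- Compound 2 `CC(C)OC(=O)c1cc(N2C(=O)C3=C(CCCC3)C2=O)ccc1Cl`: 1230 nM
- Compound 3 `CC(C)OC(=O)c1cc(N2C(=O)C3=C(CCCC3)C2=O)c(F)cc1Cl`: 13.8 nM

Compound 2, at 1230 nM, sits within the scatter of compound 1, while compound 3 lies far lower at 13.8 nM. The unmeasured compound 4 `C#CCOc1cc(N2C(=O)C3=C(CCCC3)C2=O)ccc1Cl` has propargyloxy in place of isopropoxycarbonyl on an aromatic carbon. Among the compounds with values here, no measured step makes this swap. The closest evidence is a 1.1-fold higher number from compound 1 to compound 2 (0.04 log units; within the scatter), where isopropyl replaces propyl within the group that leaves here. That small step shows only that this one alteration changed little, not what removing the whole group would do. Compound 4 has no fluoro group, so the large step of an 89-fold lower number from compound 2 to compound 3 (1.95 log units; beyond the scatter) should not carry over. A modest move toward stronger inhibition is therefore a tentative expectation, with wide uncertainty. The expected change is a 2.5-fold lower number from compound 2 to compound 4 (0.39 log units; beyond the scatter). In this assay, the estimate for compound 4 is 500 nM, with an expected range of 90 nM to 2800 nM.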

Compound 4, half-maximal inhibitory concentration: 100 nM
Estimate against measurement, compound 4: 5.0-fold (0.70 log units) above; measured number inside the range.
By their numbers in this assay, from the lowest: compound 3; then compound 4; then compounds 1 and 2 (each within the scatter of the next).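

At this position, on an aromatic carbon ortho to a chloro group, the whole group can be exchanged, and the effect is large. In this assay, propargyloxy in place of isopropoxycarbonyl gives a 12-fold lower number from compound 2 to compound 4 (1.09 log units; beyond the scatter), and propargyloxy in place of propoxycarbonyl gives an 11-fold lower number from compound 1 to compound 4 (1.05 log units; beyond the scatter). Swapping propyl for isopropyl had altered only the chain within the group, so these are the first steps to show that a change at this position can strengthen inhibition, though nothing available explains why.

From the compounds shown here alone, it remains open whether adding the fluoro group that separates compound 3 from compound 2 would strengthen inhibition in compound 4 as well. It is also unclear whether the triple bond or the loss of the carbonyl matters more, which a propoxy or methoxy group at this position could help to separate.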